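Ester side chain swaps on a glycosylated core

The source may report more compounds than this note shows. Statements on the series, on what has been measured and on what is new or still open speak of the compounds shown alone.

compound 1 `C/C=C1/[C@H](O[C@@H]2O[C@H](CO)[C@@H](O)[C@H](O)[C@H]2O)OC=C(C(=O)OC)[C@H]1CC(=O)OCCc1ccc(O)c(O)c1` — 160000 nM
compound 2 `C/C=C1/[C@H](O[C@@H]2O[C@H](CO)[C@@H](O)[C@H](O)[C@H]2O)OC=C(C(=O)OC)[C@H]1CC(=O)OCCc1ccc(F)cc1` — limit, > 20000 nM
compound 3 `C/C=C1/[C@H](O[C@@H]2O[C@H](CO)[C@@H](O)[C@H](O)[C@H]2O)OC=C(C(=O)OC)[C@H]1CC(=O)OCCc1ccc(OC)cc1` — limit, > 20000 nM

In a functional assay on SK-BR-3 cells (Homo sapiens) for antiproliferative activity, read by MTT assay, with a stated time of 72 h (a lower number here means a stronger inhibitor, a higher number a weaker inhibitor), compound 1 gives 160000 nM. Compound 2 gives only a limit, > 20000 nM. Compound 3 likewise gives only a limit, > 20000 nM. Compound 3 therefore stands at the limit of > 20000 nM in this assay, at which 2 of the 3 values shown sit, with no number of its own. The three measured steps, a step that the limit leaves unreadable from compound 1 to compound 2, a step that the limit leaves unreadable from compound 1 to compound 3 and a step that the two limits leave unreadable from compound 2 to compound 3, are all left unreadable by these limits, so none of them gives a size that can be carried over.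

Compound 4 is `C/C=C1/[C@H](O[C@@H]2O[C@H](CO)[C@@H](O)[C@H](O)[C@H]2O)OC=C(C(=O)OC)[C@H]1CC(=O)OCc1ccco1`. Compared with compound 3 the change is furan-2-yl in place of 4-methoxybenzyl on a saturated chain carbon bound to an oxygen next to a carbonyl group. For the measured compounds named here, no measured step covers this change, and the steps that exist have no readable size. The account therefore expects compound 4 to remain near the limit, with a step that the limit leaves unreadable from compound 3 to compound 4 that is estimated to lie within the scatter. Compound 4 is estimated at 40000 nM in this assay, with a range from 15000 nM to 160000 nM.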

Compound 4, half-maximal inhibitory concentration: > 15000 nM
Compound 4 was reported as a limit (the forecaster's own chance of this, stated with the estimate: 80%); the middle value does not contradict the limit.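

Compound 4 is reported only as a limit, so its steps from compound 1, compound 2 and compound 3 cannot be read, and no new step size emerges. The compounds shown leave open how compound 2, compound 3 and compound 4 truly rank against compound 1 in this assay.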